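Fluoro to hydroxy on the aromatic carbon of compound 2

The source may hold more compounds than are shown below. What is called first, only, known or untested is meant among the compounds shown, and "the series" means these compounds.

Compound 2 `CN(C)C(=O)c1cc2cnc(Nc3ccc(C(=O)NCCCN=C=S)cc3F)nc2n1C1CCCC1` gives 78.5% in a functional assay on NCI-H1299 cells (Homo sapiens) for inhibition, read by CCK-8 assay, with a stated time of 72 h, tested at 10 uM; a lower number here means a weaker effect, a higher number a stronger effect of the compound at the concentration tested. Among the three numbers so far, compound 2 stands second highest: its nearest neighbour is compound 3 `CN(C)C(=O)c1cc2cnc(Nc3ccc(C(=O)NCCCCCCN=C=S)cc3F)nc2n1C1CCCC1` with 77.6%, a gap within the scatter, and the furthest is compound 1 `CN(C)C(=O)c1cc2cnc(Nc3ccc(C(=O)NCCCN=C=S)cc3)nc2n1C1CCCC1` with 91.2%, a gap beyond it. The step of a number 12.7 percentage points lower from compound 1 to compound 2 (beyond the scatter) is a modest loss, while the step of a number 0.9 percentage points lower from compound 2 to compound 3 (within the scatter) changes nothing beyond the scatter.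

Compound 4 `CN(C)C(=O)c1cc2cnc(Nc3ccc(C(=O)NCCCN=C=S)cc3O)nc2n1C1CCCC1` differs from compound 2 by hydroxy in place of fluoro on an aromatic carbon. Among the measured compounds shown here, only one measured step touches this aromatic carbon, the step from compound 1 to compound 2, where fluoro in place of hydrogen gave the modest loss noted above. For the measured compounds named here, no measured compound carries a hydroxy anywhere, so the direction of the present exchange has no anchor; the hydrogen parent and the fluoro analogue bracket the likely outcome, and a number between them, or close to compound 2, is the plain reading. The step expected in this assay is a number 3.5 percentage points higher from compound 2 to compound 4 (within the scatter), within the scatter. Compound 4 is therefore estimated at 82% in this assay, with a range from 65% to 94%.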

Compound 4, a percentage reported as inhibition, at one concentration (the size of the read-out at that concentration, not a potency): 24.2%
Compound 4: middle estimate off by 57.8 percentage points, on the high side; measured number below the stated range.
By their numbers in this assay, from the lowest: compound 4; then compounds 3 and 2 (each within the scatter of the next); then compound 1.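

Hydrogen and fluoro do not bracket hydroxy on this aromatic carbon: in this assay, hydroxy in place of fluoro gives a number 54.3 percentage points lower from compound 2 to compound 4 (beyond the scatter) and hydroxy in place of hydrogen gives a number 67 percentage points lower from compound 1 to compound 4 (beyond the scatter), both large, whereas fluoro in place of hydrogen gave only the modest a number 12.7 percentage points lower from compound 1 to compound 2 (beyond the scatter). The position is thus far more sensitive to the identity of the group than the earlier compounds showed, and the heavy-atom count does not account for the difference, as fluoro and hydroxy each have one heavy atom; what the exchange adds by count is one hydrogen-bond donor and one hydrogen-bond acceptor, though the series cannot say whether either matters. No measurement at hand bears on the reason for this loss, which stands as an observation only.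

Still open, as far as these compounds go, is whether the loss is specific to hydroxy or extends to other groups on this carbon, such as methoxy or an amine. Also open, from the compounds shown here alone, is whether hydroxy in place of fluoro carries the same cost on the longer chain of compound 3.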